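Trifluoromethyl on another aromatic carbon of compound 1

The source may hold more compounds than are shown below. What is called first, only, known or untested is meant among the compounds shown, and "the series" means these compounds.

In an ADME assay on MDCK cells (Canis lupus familiaris) for permeability, in the apical to basolateral direction (a higher number here means that the compound crosses the layer faster, a lower number that the compound crosses the layer more slowly), compound 1 (`CC1(C)OCc2c(Nc3n[nH]c4ccccc34)nc(-c3cn[nH]c3)nc21`) gives 6.7 10^-6 cm/s and compound 2 (`CC1(C)OCc2c(Nc3n[nH]c4c(C(F)(F)F)cccc34)nc(-c3cn[nH]c3)nc21`) gives 8.5 10^-6 cm/s on the same scale, two numbers within the scatter of each other. Compound 3 (`CC1(C)OCc2c(Nc3n[nH]c4cc(C(F)(F)F)ccc34)nc(-c3cn[nH]c3)nc21`) has not been measured yet. Its change from compound 1 is trifluoromethyl in place of hydrogen on an aromatic carbon of the shared core. Among the compounds with values here, the one measured step of this kind (a 1.3-fold higher number from compound 1 to compound 2 (0.10 log units; within the scatter)) lay within the scatter, so no step beyond the scatter is expected in this assay here. The estimated step is a 1.1-fold higher number from compound 1 to compound 3 (0.05 log units; within the scatter) and no more than that. Compound 3 is expected at 7.5 10^-6 cm/s within a range of 3.5 10^-6 cm/s to 14 10^-6 cm/s in this estimate.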

Compound 3, apparent permeability: 10.3 10^-6 cm/s
Estimate against measurement, compound 3: 1.4-fold (0.14 log units) below; the measured number falls inside the stated range.
By their numbers in this assay, from the lowest: compounds 1, 2 and 3 (each within the scatter of the next).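

With trifluoromethyl on this second aromatic carbon, meta to a fused ring and para to a fused ring, this assay gives a 1.5-fold higher number from compound 1 to compound 3 (0.19 log units; within the scatter) and stays within the scatter. The change has now been read at two different aromatic carbons of the shared core, and at neither does the step leave the scatter. Nothing measured here explains these numbers.

The compounds shown leave open whether a different group on this carbon, such as an amine or a carboxylic acid, would step beyond the scatter in this assay.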